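The compounds below may be only part of what the source reports. "The series", "measured", "known", "first", "only" and "open" are said of these compounds alone.

Of the compounds shown here, three have so far been measured in an assay for inhibition of HSP60/HSP10 (Homo sapiens), with a stated time of 60 min (a lower number here means a stronger inhibitor, a higher number a weaker inhibitor), and every one of them returned only a limit. Compound 1 `O=C(Nc1cccc(Cl)c1)c1cc(Br)cc(Br)c1` gives > 100000 nM, which is a limit of the assay. Compound 2 `O=C(Nc1ccc(Sc2nc3ccccc3s2)c(Cl)c1)c1cccc(Br)c1` gives > 100000 nM, again a limit. Compound 3 `O=C(Nc1ccc(Sc2nc3ccccc3s2)cc1)c1cccc(Br)c1` gives > 100000 nM, also a limit. The step from compound 2 to compound 3 a step that the two limits leave unreadable from compound 2 to compound 3 cannot be read because of the limit of > 100000 nM in this assay, at which 3 of the 3 values shown sit. Compound 2 therefore stands only at a limit, as do the two other values shown. Compound 4 `O=C(Nc1ccc(Sc2nc3ccccc3s2)c(Cl)c1)c1ccccc1` differs from compound 2 by hydrogen in place of bromo on an aromatic carbon. Among the measured compounds shown here, no measured step bears on this change, since all values sit at the limit of > 100000 nM in this assay, at which 3 of the 3 values shown sit. Compound 4 is expected to remain at the limit, a step that the limit leaves unreadable from compound 2 to compound 4, with an estimate of 150000 nM and a range from 50000 nM to 500000 nM.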

Compound 4, half-maximal inhibitory concentration: > 100000 nM
Compound 4 ended at the assay's limit (the forecaster's own chance of this, stated with the estimate: 85%); the middle value lies beyond the limit too.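

No step can be read between compound 2 and compound 4, because both values are limits of the assay: the limit of > 100000 nM in this assay, at which 4 of the 4 values shown sit.

The compounds shown leave open what the bromo group contributes, and which change, if any, would bring a value inside that limit.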